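Cyclopentylmethyl to Oxolan-2-yl on the Amide Carbonyl

A few compounds are considered here, and "the series" means these few. Any claim that something is new, unique, unknown or untested is made for them only; others in the source may bear on it.

compound 1 `CC1CCCN1C1CCN(c2ccc(NC(=O)CC3CCCC3)cc2)C1`: in an assay on CHO cells for displacement of a labelled ligand from histamine receptor H3 (Macaca mulatta) (on this read-out lower numbers stand for stronger inhibition and higher numbers for weaker inhibition), compound 1 gives 3.1 nM
compound 2 `Cc1cc(NC(=O)C2CCOCC2)ccc1N1CCC(N2CCCC2C)C1`: in this assay compound 2 gives 17 nM

For the measured compounds named here, of the two numbers so far, compound 1 holds the lowest; compound 2 sits above it by a gap beyond the usual scatter. Compound 3 `CC1CCCN1C1CCN(c2ccc(NC(=O)C3CCCO3)cc2)C1` differs from compound 1 by oxolan-2-yl in place of cyclopentylmethyl on a carbonyl carbon. Going by the values given here, no measured pair isolates this change, so its effect is an expectation only. The change is estimated to read a 3.2-fold higher number from compound 1 to compound 3 (0.51 log units; beyond the scatter), a modest shift toward a higher number. Compound 3 is estimated at 10 nM in this assay, with a range from 3 nM to 35 nM.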

Compound 3, inhibition constant: 8.7 nM
Compound 3: middle estimate off by 1.1-fold (0.06 log units), on the high side; the range from low to high includes it.
By their numbers in this assay, from the lowest: compound 1; then compounds 3 and 2 (each within the scatter of the next).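

For the compounds shown here, with the rest of compound 1 held fixed, this is the first direct reading at this position: in this assay, the change to oxolan-2-yl gives a 2.8-fold higher number from compound 1 to compound 3 (0.45 log units; beyond the scatter). The change adds a hydrogen-bond acceptor and also alters the heavy-atom count and ring attachment, so this one step cannot separate these differences. No available evidence bears on the reason for the step.

Still open, as far as these compounds go, is how cyclopentyl attached directly to the carbonyl carbon, or an open methoxyethyl chain, would read on the core of compound 1.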